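The source may hold more compounds than are shown below. What is called first, only, known or untested is meant among the compounds shown, and "the series" means these compounds.

Compound 1 `COc1ccc(C2=NOC(c3c[nH]c4ccccc34)C2)cc1OC`, compound 2 `Fc1ccc2c(C3CC(c4ccncc4)=NO3)c[nH]c2c1` and compound 3 `COc1cc(C2=NOC(c3c[nH]c4ccccc34)C2)cc(OC)c1OC` were tested in a functional assay on HEK293 cells (Homo sapiens) for inhibition, read by MTT assay, with a stated time of 48 h; on this read-out higher numbers stand for weaker inhibition and lower numbers for stronger inhibition.
Compound 1 reaches only a limit of the assay, > 100000 nM.
Compound 2 gives 9500 nM.
Compound 3 gives 5000 nM.

Compound 3 thus holds the lower of the two numbers, though compound 2 lies within the scatter of it; compound 1 is a limit only. Compound 4 `COc1ccc2[nH]cc(C3CC(c4cc(OC)c(OC)c(OC)c4)=NO3)c2c1` differs from compound 3 by methoxy in place of hydrogen on an aromatic carbon. For the measured compounds named here, the one measured step with the same kind of change, an at least 20-fold lower number from compound 1 to compound 3 (1.30 log units; beyond the scatter), was large, but it sits on a different ring of the core, so it offers only loose guidance here. The expected step is a 1.3-fold lower number from compound 3 to compound 4 (0.10 log units; within the scatter), within the scatter. Compound 4 is therefore estimated to give about 4000 nM, in the range 1500 nM to 12000 nM.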

Compound 4, half-maximal inhibitory concentration: 45400 nM
Compound 4: the middle estimate sits 11-fold (1.05 log units) below what was measured; measured number above the stated range.
By their numbers in this assay, from the lowest: compounds 3 and 2 (each within the scatter of the next); then compound 4. At a limit, above all of these: compound 1.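

In this assay, methoxy in place of hydrogen on the fused ring system gives a 9.1-fold higher number from compound 3 to compound 4 (0.96 log units; beyond the scatter), which means weaker inhibition. The same kind of change went the other way at a different place, with an at least 20-fold lower number from compound 1 to compound 3 (1.30 log units; beyond the scatter), so among these compounds its result depends on where the methoxy sits. That earlier step starts from compound 1, which stands at a limit: the limit of > 100000 nM in this assay, at which 1 of the 4 values shown sits.

The compounds shown leave open whether a hydroxyl or an amine at this position would keep the number near that of compound 3. They also leave open whether a longer chain, such as ethoxy, would raise it further.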